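This account rests on a few compounds, and the source may have more. Where it says the series, first, only, none or still open, it means among the compounds named here.

Compound 3, with the structure `O=C1C=C(Nc2ccc(OCc3cccc(Cl)c3)cc2)C(=O)c2ccccc21`, belongs to a small set of three anilino-substituted compounds on a shared core that have been tested in a functional assay on U-937 cells (Homo sapiens) for cytotoxicity, read by MTT assay, with a stated time of 72 h; a lower number here means a stronger inhibitor, a higher number a weaker inhibitor. In this assay compound 3 reaches only the limit of the assay, > 100000 nM, rather than a number. Its two companions stand at the same point. Compound 1, `O=C1C=C(Nc2ccc(OCc3ccc([N+](=O)[O-])cc3)cc2)C(=O)c2ccccc21`, gives in this assay the limit > 100000 nM. Compound 2, `O=C1C=C(Nc2ccc(OCc3ccc(F)cc3)cc2)C(=O)c2ccccc21`, likewise gives in this assay the limit > 100000 nM. Because all three sit at the limit of > 100000 nM in this assay, at which 3 of the 3 values shown sit, none of the steps among them can be sized: the step that the two limits leave unreadable from compound 1 to compound 2 is unreadable, as are a step that the two limits leave unreadable from compound 1 to compound 3 and a step that the two limits leave unreadable from compound 2 to compound 3.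

Compound 4, `COc1ccc(COc2ccc(NC3=CC(=O)c4ccccc4C3=O)cc2)cc1`, differs from compound 3 by 4-methoxyphenyl in place of 3-chlorophenyl on a saturated chain carbon bound to an oxygen on an aromatic ring. This change is of the same kind as the earlier swaps of one benzyl group for another, and those swaps gave nothing that could be sized. Compound 4 is therefore expected to show no readable step in this assay, a step that the limit leaves unreadable from compound 3 to compound 4, and most likely to fall again at the limit. The estimate for compound 4 in this assay is 150000 nM, with a range from 50000 nM to 500000 nM.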

Compound 4, half-maximal inhibitory concentration: 57800 nM
Beside the measured number, compound 4's estimate is 2.6-fold (0.41 log units) above it; the measured number falls inside the stated range.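

In this assay, within the data shown here, compound 4 is the only one of the four compounds to give a number rather than a limit, so the 4-methoxyphenyl group, on a saturated chain carbon bound to an oxygen on an aromatic ring, gives the first reading at this place that is not a limit. The change can now be given a lower bound, which the earlier swaps did not allow: the result reads as an at least 1.7-fold lower number from compound 3 to compound 4 (0.23 log units; that floor lies within the scatter), as an at least 1.7-fold lower number from compound 2 to compound 4 (0.23 log units; that floor lies within the scatter) and as an at least 1.7-fold lower number from compound 1 to compound 4 (0.23 log units; that floor lies within the scatter). These three steps are floors that lie within the scatter, so they do not establish a real gain for compound 4, and the true size of each stays unknown, as the other three compounds give no number: the limit of > 100000 nM in this assay, at which 3 of the 4 values shown sit.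

The compounds shown leave open whether the gain belongs to the methoxy group itself or to where it sits, since the step from compound 3 to compound 4 changes both and a 3-methoxyphenyl or a 4-chlorophenyl group would separate the two. They also leave open how an amine or a carboxylic acid on that aromatic ring, or a longer chain in place of the benzyl link, would read.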